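Fluoro for chloro: a one-atom swap

This account rests on a few compounds, and the source may have more. Where it says the series, first, only, none or still open, it means among the compounds named here.

compound 1 `COc1cc(OC)c(C(=O)/C=C/c2ccc(Cl)cc2)c(OC)c1` — 6500 nM
compound 2 `COc1cc(O)c(C(=O)/C=C/c2ccccc2SC)c(OC)c1` — 8900 nM

In a functional assay on RL cells (Homo sapiens) for cytotoxicity, with a stated time of 48 h (a lower number here means a stronger inhibitor, a higher number a weaker inhibitor), compound 1 gives 6500 nM and compound 2 gives 8900 nM. Compound 1 stands at the lower of the two numbers, but the gap to compound 2 falls within the scatter, so the pair shows no difference. Going by the values given here, no step between measured compounds is available.

Compound 3 `COc1cc(OC)c(C(=O)/C=C/c2ccc(F)cc2)c(OC)c1` differs from compound 1 in one place: fluoro in place of chloro on an aromatic carbon. With nothing measured to anchor this change, the step of a 1.2-fold higher number from compound 1 to compound 3 (0.09 log units; within the scatter) is expected to stay within the scatter, with no clear direction. For compound 3 a value of 8000 nM is estimated, in the range 3500 nM to 20000 nM.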

Compound 3, half-maximal inhibitory concentration: 6400 nM
The estimate for compound 3 lay 1.3-fold (0.10 log units) above the measured number; the measured number falls inside the stated range.
By their numbers in this assay, from the lowest: compounds 3, 1 and 2 (each within the scatter of the next).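

Fluoro in place of chloro on this aromatic carbon gives a 1.0-fold lower number from compound 1 to compound 3 (0.01 log units; within the scatter) in this assay and stays within the scatter. Going by these compounds alone, this is the first one-place comparison, and at this place on the shared core the assay does not separate 4-chlorophenyl from 4-fluorophenyl. No measured evidence bears on this result.

The compounds shown cover only these two halogens at this place, so a non-halogen group there, such as an amine or a carboxylic acid, remains open. From the compounds shown here alone, compound 2 differs from compound 1 in more than one place, so the separate contributions of its changes also remain open.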